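Adding a chloro group to a hydrazone-type inhibitor

This account rests on a few compounds, and the source may have more. Where it says the series, first, only, none or still open, it means among the compounds named here.

Three compounds share a core built around a five-membered ring and a phenol: compound 1 `O=C(CBr)N1N=C(c2ccc(F)cc2)CC1c1ccccc1O`, compound 2 `Cc1ccc(C2=NN(C(=O)CBr)C(c3cc(Cl)ccc3O)C2)cc1` and compound 3 `O=C(CN1CCCCC1)N1N=C(c2ccccc2)CC1c1ccccc1O`. In an assay on isolated protein for inhibition of Amine oxidase [flavin-containing] A (Homo sapiens), read by fluorescence, with stated times of 15 min and 20 min (a higher number here means a weaker inhibitor, a lower number a stronger inhibitor), compound 3 gives 9510 nM, while compound 1 at 6000 nM and compound 2 at 5220 nM sit within the usual scatter of it, so no ordering among the three can be read from these numbers. Compound 4 `O=C(CN1CCCCC1)N1N=C(c2ccc(Cl)cc2)CC1c1ccccc1O` has not yet been measured; it differs from compound 3 by chloro in place of hydrogen on an aromatic carbon. Among the measured compounds shown here, with no measured step of this kind available, only a small change is expected, if any, and the step from compound 3 to compound 4 is estimated at a 1.6-fold lower number from compound 3 to compound 4 (0.20 log units; within the scatter). Compound 4 is therefore expected to give about 6000 nM, somewhere between 2500 nM and 15000 nM.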

Compound 4, half-maximal inhibitory concentration: 7250 nM
Compound 4: middle estimate off by 1.2-fold (0.08 log units), on the low side; the range from low to high includes it.
By their numbers in this assay, from the lowest: compounds 2, 1, 4 and 3 (each within the scatter of the next).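

Going from phenyl to 4-chlorophenyl gives the first direct measure of a change at this place, para to a large group: in this assay the result is a 1.3-fold lower number from compound 3 to compound 4 (0.12 log units; within the scatter), so adding this single chlorine atom does not shift the reading measurably. No measurement at hand offers an explanation for this result. Going by these compounds, whether a different group at the same place, such as a nitrile, an amine or a carboxylic acid, would move the number beyond the scatter remains open.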